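From 2-fluorophenyl to 4-(trifluoromethyl)phenyl on a shared core

The source may report more compounds than this note shows. Statements on the series, on what has been measured and on what is new or still open speak of the compounds shown alone.

Compound 1 (`O=C(Nc1ccccc1F)Nc1cc2ncncc2cc1OCc1ccccc1`) : 5900 nM
Compound 2 (`O=C(Nc1ccccc1F)Nc1cc2ncncc2cc1OCc1ccccc1F`) : 3800 nM
Compound 3 (`O=C(Nc1ccc(C(F)(F)F)cc1)Nc1cc2ncncc2cc1OCc1ccccc1`) : not yet measured

Among the compounds with values here, in a functional assay on GBM3 cells (Homo sapiens) for antiproliferative activity, read by WST assay, with a stated time of 72 h (a lower number here means a stronger inhibitor, a higher number a weaker inhibitor), compound 1 stands level with compound 2, the only other measured compound, and the data show a 1.6-fold lower number from compound 1 to compound 2 (0.19 log units; within the scatter) for fluoro in place of hydrogen on an aromatic carbon. That single step leaves untouched the group that changes next. Compound 3 differs from compound 1 by 4-(trifluoromethyl)phenyl in place of 2-fluorophenyl on an amide-type nitrogen and thus carries 4-(trifluoromethyl)phenyl in place of 2-fluorophenyl on an amide-type nitrogen. Within the data shown here, no measured step replaces that group, so the data offer no direction for this change, and no step beyond the scatter is expected in this assay on present evidence. The expected change is a 1.3-fold lower number from compound 1 to compound 3 (0.12 log units; within the scatter) and remains loosely bounded. Compound 3 is estimated at 4500 nM with 1200 nM to 15000 nM as the expected range.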

Compound 3, half-maximal inhibitory concentration: 3700 nM
Compound 3: the middle estimate sits 1.2-fold (0.09 log units) above what was measured, within the range that was stated.
By their numbers in this assay, from the lowest: compounds 3, 2 and 1 (each within the scatter of the next).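

In this assay, within the data shown here, the group on the amide-type nitrogen is replaced for the first time, and 4-(trifluoromethyl)phenyl in place of 2-fluorophenyl gives a 1.6-fold lower number from compound 1 to compound 3 (0.20 log units; within the scatter) on the shared core. This nitrogen thus carries a larger aryl group, with three fluorine atoms instead of one, and the step still stays within the scatter, so the swap shows no real effect in this assay. Nothing available explains this outcome.

On these data alone, whether a group of another kind on this nitrogen, such as an amine, a carboxylic acid or a longer chain, would give a step beyond the scatter remains open. Also open, as far as these compounds go, is how the two aryl groups would compare with an unsubstituted phenyl on this nitrogen.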